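Hydroxymethyl entering the chain of compound 2

The source may report more compounds than this note shows. Statements on the series, on what has been measured and on what is new or still open speak of the compounds shown alone.

compound 1 `COCCNC(=O)c1cc2cccc(OC)c2oc1=N` — in an assay on HEK293 cells for displacement of a labelled ligand from adenosine receptor A2b (Homo sapiens), read by scintillation counting, with a stated time of 30 min, tested at 10 uM (a higher number here means more inhibition at the concentration tested (going by the name of the read-out), a lower number less inhibition), compound 1 gives 43%
compound 2 `COc1cccc2cc(C(=O)NCC(=O)O)c(=O)oc12` — in this assay compound 2 gives 35%

Among the measured compounds shown here, compound 2 holds the lower of the two numbers measured so far, while compound 1 stands higher by a margin that falls within the scatter, so no order between the two can be read. The two measured compounds differ from one another in more than one place, and their gap cannot be assigned to any single change.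

Compound 3 `COc1cccc2cc(C(=O)N[C@@H](CO)C(=O)O)c(=O)oc12` has not been measured. Relative to compound 2 the difference is hydroxymethyl in place of hydrogen on a saturated chain carbon bound to an amide-type nitrogen and a carbonyl carbon. For the measured compounds named here, no measured pair shows this change or one like it, so nothing among the numbers above speaks for or against it.

The step of a number 2 percentage points lower from compound 2 to compound 3 (within the scatter) is expected to remain within the scatter, with neither direction favoured. For compound 3 the estimate in this assay is 33%, expected to fall between 15% and 52%.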

Compound 3, a percentage reported as inhibition, at one concentration (the size of the read-out at that concentration, not a potency): 24%
The estimate for compound 3 lay 9 percentage points above the measured number; measured number inside the range.
By their numbers in this assay, from the lowest: compound 3; then compounds 2 and 1 (each within the scatter of the next).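

In this assay, among the compounds shown here, the step of a number 11 percentage points lower from compound 2 to compound 3 (beyond the scatter) is the first reading of any single change. It shows that the saturated chain carbon bound to an amide-type nitrogen and a carbonyl carbon is not indifferent to substitution: with hydroxymethyl in place of hydrogen, the carboxymethyl chain of compound 2 becomes the 1-carboxy-2-hydroxyethyl chain of compound 3, and inhibition at the concentration tested is lower, though only modestly. This rests on one pair and one group, and nothing at hand accounts for the step.

Open is whether the step follows the hydroxyl or the added carbon: a methyl group or a longer chain such as 2-hydroxyethyl on the same carbon would separate the two, and neither stands among the compounds shown. Also open, as far as these compounds go, are the opposite configuration at this carbon and the effect of hydroxymethyl on a chain ending in a primary amide or an amine instead of the carboxylic acid.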